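Cyclohexyl in place of phenyl on the diene carbon

The source may hold more compounds than are shown below. What is called first, only, known or untested is meant among the compounds shown, and "the series" means these compounds.

Among the measured compounds shown here, compound 2 `COc1ccc(/C(=C/C=C/C(=O)N[C@H](C)CCCc2cccnc2)c2ccccc2)cc1` gives 0.16 mg/kg in a functional assay with platelet-activating factor receptor (Cavia porcellus) as the target (on this read-out higher numbers stand for an effect only at larger amounts of compound and lower numbers for an effect already at smaller amounts), the lowest of the two numbers so far; the other belongs to compound 1 `CCCC/C(=C\C=C\C(=O)N[C@H](C)CCCc1cccnc1)c1ccc(OC)cc1`, which in this assay gives 0.68 mg/kg. For the measured compounds named here, the only measured step is a 4.3-fold lower number from compound 1 to compound 2 (0.63 log units; beyond the scatter). Compound 3 `COc1ccc(/C(=C/C=C/C(=O)N[C@H](C)CCCc2cccnc2)C2CCCCC2)cc1` differs from compound 2 by cyclohexyl in place of phenyl on a double-bonded chain carbon bound to an aromatic carbon and a double-bonded chain carbon. Going by the values given here, no measured step covers this change directly: the one known step swaps butyl for phenyl, and cyclohexyl is neither of these. A non-aromatic ring entering at the place where the aromatic ring sat gives no firm direction, so compound 3 is expected to fall between the two measured values. The expected step in this assay is a 2.5-fold higher number from compound 2 to compound 3 (0.40 log units; beyond the scatter), a moderate rise that stays inside the span already seen. Compound 3 is therefore estimated at 0.4 mg/kg in this assay, with a range from 0.15 mg/kg to 1.2 mg/kg.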

Compound 3, dose for 50% inhibition: 0.21 mg/kg
Compound 3: the middle estimate sits 1.9-fold (0.28 log units) above what was measured; measured number inside the range.
By their numbers in this assay, from the lowest: compounds 2 and 3 (each within the scatter of the next); then compound 1.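

At this place on the double-bonded chain carbon, an aromatic ring is not required in this assay: the swap of phenyl for cyclohexyl gives a 1.3-fold higher number from compound 2 to compound 3 (0.12 log units; within the scatter). The change from butyl to cyclohexyl gives a 3.2-fold lower number from compound 1 to compound 3 (0.51 log units; beyond the scatter), so among these three compounds both six-membered carbon rings give lower numbers than the open butyl chain, and neither compound goes against this. Nothing available explains why butyl differs from the two rings.

The compounds shown leave open whether ring size or the branching at the attachment carbon is what separates cyclohexyl from butyl, which cyclopentyl, cyclopropyl or isopropyl at this place could help settle. They also leave open whether a ring carrying an amine or a carboxylic acid would fit this place equally well.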